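The compounds below may be only part of what the source reports. "The series", "measured", "known", "first", "only" and "open" are said of these compounds alone.

In a functional assay on Hep cells (Homo sapiens) for cytotoxicity, read by sulforhodamine B assay, with a stated time of 48 h (a lower number here means a stronger inhibitor, a higher number a weaker inhibitor), the measured compounds stand as follows:
Compound 1 `CC1=C(/C=C/C(=O)/C=C/c2ccc(Cl)cc2)C(C)(C)CCC1` gives 90600 nM.
Compound 2 `CC1=C(/C=C/C(=O)/C=C/c2ccccc2Cl)C(C)(C)CCC1` gives 54200 nM.

Compound 2 holds the lowest of the two numbers in this assay, with compound 1 the nearest; the step of a 1.7-fold lower number from compound 1 to compound 2 (0.22 log units; within the scatter) lies within the scatter, so the two compounds cannot be ranked against each other. Compound 3 `CC1=C(/C=C/C(=O)/C=C/c2ccccc2[N+](=O)[O-])C(C)(C)CCC1` differs from compound 2 by nitro in place of chloro on an aromatic carbon. Among the measured compounds shown here, no measured step exchanges the group on that aromatic carbon; the only step available, a 1.7-fold lower number from compound 1 to compound 2 (0.22 log units; within the scatter), moves the chloro group from one aromatic carbon to another and is itself within the scatter. For the measured compounds named here, the change to a nitro group therefore rests on no measured precedent, and the data point in neither direction. Compound 3 is expected to give a number close to that of compound 2, a step of a 1.2-fold lower number from compound 2 to compound 3 (0.08 log units; within the scatter), which is no change beyond the scatter. The estimate for compound 3 in this assay is 45000 nM, within a range from 15000 nM to 150000 nM.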

Compound 3, half-maximal inhibitory concentration: 44900 nM
Compound 3: middle estimate off by 1.0-fold (0.00 log units), on the high side; low and high end bracket the measured number.
By their numbers in this assay, from the lowest: compounds 3, 2 and 1 (each within the scatter of the next).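

In this assay the exchange of chloro for nitro on an aromatic carbon ortho to a large group gives a 1.2-fold lower number from compound 2 to compound 3 (0.08 log units; within the scatter) and so adds a measured change of group at this position, where the earlier step only moved the chloro group from one aromatic carbon to another. Here a group of three heavy atoms with two hydrogen-bond acceptors replaces a single chlorine atom with no change beyond the scatter, and the two compounds cannot be ranked against each other. Nothing at hand explains this outcome.

The three compounds shown carry only chloro or nitro on the aromatic ring, so it remains open whether an amine or a carboxylic acid on this aromatic carbon would shift the number beyond the scatter. On these data alone, it also remains open whether nitro at the ring position held by chloro in compound 1 would do so.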